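The compounds below may be only part of what the source reports. "The series", "measured", "known", "first", "only" and "open" are said of these compounds alone.

In a physicochemical assay for lipophilicity (a lower number here means a more polar compound, a higher number a more lipophilic compound), compound 1 `CCCCCCNC(=O)Oc1ccc(Cl)cc1C(=O)Nc1ccc(Cl)c(Cl)c1` gives 6.08. Compound 2 `CCCCCCCNC(=O)Oc1ccc(Cl)cc1C(=O)Nc1ccc(Cl)c(Cl)c1` carries methyl in place of hydrogen on a saturated chain carbon, six bonds along the chain from an amide-type nitrogen, and in this assay compound 2 gives 6.5, a step of a number 0.42 log units higher from compound 1 to compound 2 (beyond the scatter). Compound 3 `CCCCCCNC(=O)Oc1ccc(Cl)cc1C(=O)Nc1ccc(Cl)cc1` gives 5.53 in this assay, the lowest of the three numbers, reached by a step of a number 0.55 log units lower from compound 1 to compound 3 (beyond the scatter). Compound 4 `CCCCCCCNC(=O)Oc1ccc(Cl)cc1C(=O)Nc1ccc(Cl)cc1` has not yet been measured. It differs from compound 3 by methyl in place of hydrogen on a saturated chain carbon, six bonds along the chain from an amide-type nitrogen, the same change that separates compound 1 from compound 2, made at the same place; the two cores differ by hydrogen in place of chloro on an aromatic carbon. The step expected for compound 4 is a number 0.42 log units higher from compound 3 to compound 4 (beyond the scatter), set beside the measured a number 0.42 log units higher from compound 1 to compound 2 (beyond the scatter), and it rests on that step and on the value of compound 3 5.53. Compound 4 is therefore expected to give about 5.95 in this assay, most likely between 5.65 and 6.25.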

Compound 4, partition coefficient: 5.94
Compound 4: middle estimate off by 0.01 log units, on the high side; low and high end bracket the measured number.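

Carried to the core of compound 3, the methyl in place of hydrogen gives a number 0.41 log units higher from compound 3 to compound 4 (beyond the scatter) in this assay and so closely repeats a number 0.42 log units higher from compound 1 to compound 2 (beyond the scatter) on the core of compound 1. Read the other way, hydrogen in place of chloro gives a number 0.56 log units lower from compound 2 to compound 4 (beyond the scatter) and stands close to a number 0.55 log units lower from compound 1 to compound 3 (beyond the scatter) on the compounds without the added methyl, so the two changes add up across these four compounds, and none of them goes against this. Within the data shown here, this is only one pair of cores and one place on the chain, so it does not show that the step would carry to other cores, and nothing available explains the agreement.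

The compounds shown leave open whether the step would hold on a longer chain or on a chain ending in an amine or a carboxylic acid. They also leave open whether it would carry as closely with fluoro or methoxy in place of the chloro.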